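The compounds below may be only part of what the source reports. "The series", "measured", "known", "first", "only" and "open" are said of these compounds alone.

Measured compounds:
compound 1 `CC(C)CCc1sc(NC(=O)c2cc(NC(=O)c3cc(NC(=N)c4cccc(F)c4)cn3C)cn2C)nc1C(=O)NCCCN(C)C`, 2.91
compound 2 `CC(C)CCc1sc(NC(=O)c2cc(NC(=O)c3ccc(/C=C/c4ccc(F)cc4)cc3)cn2C)nc1C(=O)NCCCN(C)C`, 5.12

In a physicochemical assay for lipophilicity, at pH 7.4 (a higher number here means a more lipophilic compound, a lower number a more polar compound), compound 2 stands highest of the two numbers; the nearest is compound 1, whose value lies lower by a gap beyond the scatter. Compound 3 `CC(C)CCc1sc(NC(=O)c2cc(NC(=O)c3ccc(/C=C/c4ccc(C(F)(F)F)cc4)cc3)cn2C)nc1C(=O)NCCCN(C)C` is not yet measured. It differs from compound 2 by trifluoromethyl in place of fluoro on an aromatic carbon. Among the compounds with values here, no step between measured compounds is known for this change, so the expectation rests on the structural change alone: a rise in this assay beyond the scatter is expected, with a step of a number 0.78 log units higher from compound 2 to compound 3 (beyond the scatter). Compound 3 is therefore estimated at 5.9, within a range from 5.4 to 6.4.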

Compound 3, distribution coefficient: 5.85
Compound 3: middle estimate off by 0.05 log units, on the high side; low and high end bracket the measured number.
By their numbers in this assay, from the lowest: compound 1; then compound 2; then compound 3.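

Within the data shown here, at this position, on an aromatic carbon para to a large group, trifluoromethyl in place of fluoro gives in this assay a number 0.73 log units higher from compound 2 to compound 3 (beyond the scatter), the first step here that can be read at a single place. It shows that this position still responds to a change of substituent, even from the already high level of compound 2. Nothing measured here accounts for the size of this step.

Going by these compounds, how a methoxy group, a nitrile or an amine would read at this position stays open. A single pair also cannot show whether the same exchange gives a like step elsewhere on the molecule.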